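Thiophene to methylpyridine on the acyl sulfonamide

This account rests on a few compounds, and the source may have more. Where it says the series, first, only, none or still open, it means among the compounds named here.

Compound 3 `COc1ccc(-c2ccc(OCc3cc(C(=O)NS(=O)(=O)c4cccs4)oc3C)cc2)cc1` gives 3.6 nM in an assay on cells for displacement of a labelled ligand from prostaglandin E2 receptor EP4 subtype (Homo sapiens), read by scintillation counting (on this read-out lower numbers stand for stronger inhibition and higher numbers for weaker inhibition), the lowest of the three numbers recorded. Compound 2 `COc1ccc(-c2ccc(OCc3cc(C(=O)NS(=O)(=O)c4ccccc4)oc3C)cc2)c(C)c1` gives 21 nM in this assay, a gap beyond the scatter, and compound 1 `Cc1oc(C(=O)O)cc1COc1ccc(-c2ccc(Cl)cc2)cc1`, the free acid, gives 1000 nM, farther still. Compound 4 `COc1ccc(-c2ccc(OCc3cc(C(=O)NS(=O)(=O)c4ccc(C)cn4)oc3C)cc2)cc1` is compound 3 with 5-methylpyridin-2-yl in place of thiophen-2-yl on a sulfonyl sulfur. Within the data shown here, no measured pair shows this change, so the step from compound 3 to compound 4 is estimated as a 1.9-fold higher number from compound 3 to compound 4 (0.29 log units; within the scatter), a modest loss at most, since the acyl sulfonamide that carries the ring stays in place. Compound 4 is therefore expected to give about 7 nM in this assay, with a likely range from 2.5 nM to 25 nM.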

Compound 4, inhibition constant: 15 nM
Beside the measured number, compound 4's estimate is 2.1-fold (0.33 log units) below it; the measured number falls inside the stated range.
By their numbers in this assay, from the lowest: compound 3; then compounds 4 and 2 (each within the scatter of the next); then compound 1.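

Among these compounds, this is the first pair that differs in one place only, and it shows that in this assay the group on the sulfonyl sulfur matters, with 5-methylpyridin-2-yl in place of thiophen-2-yl giving a 4.2-fold higher number from compound 3 to compound 4 (0.62 log units; beyond the scatter). Among the compounds shown here, the change replaces a five-membered aromatic ring with a six-membered one and also brings in a methyl group, so the single step cannot be divided between these differences. Nothing available explains the step. Going by these compounds, whether an unsubstituted pyridin-2-yl or a 5-methylthiophen-2-yl would fall closer to compound 3 or to compound 4 remains open.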